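From Bromo to 3-Fluorophenyl: A Step Without a Starting Number

The source may report more compounds than this note shows. Statements on the series, on what has been measured and on what is new or still open speak of the compounds shown alone.

Compound 2 `COc1ccc(/C=C/C(=O)c2cccc(Br)c2)cc1` offers no starting number for this comparison. In a functional assay on HepG2 cells (Homo sapiens) for cytotoxicity, read by sulforhodamine B assay, with a stated time of 48 h (a lower number here means a stronger inhibitor, a higher number a weaker inhibitor), compound 2 has the entry "not determined" (no result reported), so it cannot be placed on the potency scale. Among the measured compounds shown here, the only measured neighbour is compound 1 `O=C(/C=C/c1ccc(Br)cc1)c1cccc(-c2cccc(F)c2)c1`, which also carries a 3-fluorophenyl group and gives 9920 nM in this assay. The next compound is compound 3 `COc1ccc(/C=C/C(=O)c2cccc(-c3cccc(F)c3)c2)cc1`, which has not yet been measured.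

The structural change is 3-fluorophenyl in place of bromo on an aromatic carbon, meta to a large group. For the measured compounds named here, no measured step shows what this swap does, and the two compounds also lack a shared number for comparison. A modest step towards stronger inhibition in this assay is expected, but that expectation is weakly supported. The best available anchor is compound 1 at 9920 nM, which suggests that compound 3 will be a weak inhibitor on this scale. For compound 3, the estimated value is 12000 nM, with an expected range from 4000 nM to 40000 nM.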

Compound 3, half-maximal inhibitory concentration: 1720 nM
Compound 3: the middle estimate sits 7.0-fold (0.84 log units) above what was measured, and the stated range ends above it.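

In this assay, among the compounds shown here, methoxy in place of bromo on an aromatic carbon, with the 3-fluorophenyl group kept in both compounds, gives a 5.8-fold lower number from compound 1 to compound 3 (0.76 log units; beyond the scatter), and this is the only measured step in the set. It shows that compounds carrying 3-fluorophenyl are not tied to one potency, since a change elsewhere in the molecule moves the number by more than the usual scatter, while the swap of bromo for 3-fluorophenyl itself still cannot be read: compound 2 has no number to start from. Nothing available explains why the number falls with methoxy.

On these data alone, what the 3-fluorophenyl group contributes compared with bromo therefore stays open, and a measured partner for compound 3 with a plain phenyl or a chlorine at that spot would be needed to judge the role of the group and its fluorine. As far as these compounds go, it is also open whether the gain belongs to methoxy in particular, or whether a hydroxyl, an amine or a longer ethoxy chain in its place would give a similar, larger or smaller step.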